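A Halogen Swap Under a Solubility Limit

The source may hold more compounds than are shown below. What is called first, only, known or untested is meant among the compounds shown, and "the series" means these compounds.

Of the compounds shown here, two have been tested in a physicochemical assay for solubility (a lower number here means a less soluble compound, a higher number a more soluble compound), and neither returns a number. Compound 1 `O=C(O)c1ccc(C(=O)/C(=C\c2ccc(F)c([N+](=O)[O-])c2)SCc2ccc(C(F)(F)F)cc2)cc1` reads < 1000 ug/mL as a limit of the assay. Compound 2 `O=C(O)c1ccc(C(=O)/C(=C\c2ccc(Cl)c([N+](=O)[O-])c2)SCc2ccc(F)cc2)cc1` reads < 1000 ug/mL as a limit of the assay, so it stands only at that limit and cannot be ranked. The next compound, compound 3 `O=C(O)c1ccc(C(=O)/C(=C\c2ccc(F)c([N+](=O)[O-])c2)SCc2ccc(F)cc2)cc1`, differs from compound 2 by fluoro in place of chloro on an aromatic carbon and this places fluoro in place of chloro on an aromatic carbon, ortho to a nitro group. Within the data shown here, no measured step shows what this swap does, so no size can be taken from the data. In this assay no change beyond the scatter is expected, in either direction, and another limit is the likeliest report. The estimated step that the limit leaves unreadable from compound 2 to compound 3 is accordingly expected to stay small. For compound 3 the expected solubility is 600 ug/mL with an estimated range from 200 ug/mL to 1000 ug/mL as its span.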

Compound 3, solubility: < 1000 ug/mL
Compound 3 ended at the assay's limit; the forecaster's own chance of this, stated with the estimate: 80%; the middle value is on the limit's open side.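

Compound 3 gives < 1000 ug/mL in this assay as a limit of the assay, and no new step can be read between it and compound 1 or compound 2. The compounds shown leave open whether swapping chloro or trifluoromethyl for fluoro changes solubility at all.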